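Swapping an Oxanyl Ethyl Group for Methylpiperidinyl

The source may hold more compounds than are shown below. What is called first, only, known or untested is meant among the compounds shown, and "the series" means these compounds.

Of the compounds shown here, two have so far been measured in a physicochemical assay for lipophilicity, at pH 7.4; on this read-out higher numbers stand for higher lipophilicity and lower numbers for lower lipophilicity. Compound 1 `CCc1ccc(N(CC(C)C)S(=O)(=O)c2ccc3c(c2)C(O)CC(C(C)C2CCOCC2)O3)cc1` gives 5.04, the higher of the two numbers. Compound 2 `CCc1ccc(N(CC(C)C)S(=O)(=O)c2ccc(OCC3CCOCC3)c3c2CCC3O)cc1` gives 4.55, a number that stands below that of compound 1 by more than the usual scatter. Going by the values given here, no two measured compounds differ in a single place, so no measured step is available to guide an expectation.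

Compound 3 `CCc1ccc(N(CC(C)C)S(=O)(=O)c2ccc3c(c2)C(O)CC(C2CCN(C)CC2)O3)cc1` has not yet been measured. It differs from compound 1 in one place: 1-methylpiperidin-4-yl in place of 1-(oxan-4-yl)ethyl on a saturated ring carbon The change sits on a saturated ring carbon of the core, in the six-membered non-aromatic ring with one oxygen that is part of the fused system of two rings.

In the absence of a measured step, a large decrease in this assay is expected from compound 1 to compound 3, a number 2.24 log units lower from compound 1 to compound 3 (beyond the scatter). The estimated value for compound 3 is 2.8, with a range from 2 to 3.6.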

Compound 3, distribution coefficient: 2.67
For compound 3 the middle estimate is 0.13 log units above the measured one; measured number inside the range.
By their numbers in this assay, from the lowest: compound 3; then compound 2; then compound 1.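

In this assay, going by these compounds alone, the only step at this position is large: 1-methylpiperidin-4-yl in place of 1-(oxan-4-yl)ethyl gives a number 2.37 log units lower from compound 1 to compound 3 (beyond the scatter). The saturated ring carbon next to the ring oxygen is therefore a place where the choice of group matters strongly to this read-out, even though both groups hold one six-membered non-aromatic ring with 1 hetero atom and have the same counts of hydrogen-bond donors and acceptors. No supporting data on the origin of this step are available.

The change replaces the ring oxygen with a methyl-bearing ring nitrogen and also alters the link to the core, so the compounds shown do not separate these two parts of the step. Directly attached oxan-4-yl, or 1-(1-methylpiperidin-4-yl)ethyl, at this carbon would divide it.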